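Thiophene to furan on a ribosylated bicyclic core

The compounds below may be only part of what the source reports. "The series", "measured", "known", "first", "only" and "open" are said of these compounds alone.

Measured compounds:
Compound 1, `Nc1nc(N)c2c(-c3ccsc3)cn([C@@H]3O[C@H](CO)[C@@H](O)[C@H]3O)c2n1` — > 20000 nM
Compound 2, `Cc1nc(N)c2c(-c3ccsc3)cn([C@@H]3O[C@H](CO)[C@@H](O)[C@H]3O)c2n1` — > 20000 nM
Compound 3, `CNc1ncnc2c1c(-c1cc3ccccc3o1)cn2[C@@H]1O[C@H](CO)[C@@H](O)[C@H]1O` — > 20000 nM

In a functional assay on HCT-116 cells (Homo sapiens), read by MTT assay, with a stated time of 72 h (on this read-out higher numbers stand for weaker inhibition and lower numbers for stronger inhibition), compound 1 gives only a limit, > 20000 nM. In this assay compound 2 also gives only a limit, > 20000 nM. Compound 3, which carries a different substituent pattern on the shared core, likewise gives only a limit in this assay, > 20000 nM. Compound 2 therefore stands at the limit of the assay, and so do the two other measured compounds; every value shown sits there, as the limit of > 20000 nM in this assay, at which 3 of the 3 values shown sit, records. Going by the values given here, the one step that connects two measured compounds, a step that the two limits leave unreadable from compound 1 to compound 2, cannot be read in size for that reason.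

Compound 4, `Cc1nc(N)c2c(-c3ccoc3)cn([C@@H]3O[C@H](CO)[C@@H](O)[C@H]3O)c2n1`, differs from compound 2 in a single place: furan-3-yl in place of thiophen-3-yl on an aromatic carbon. Among the compounds with values here, no measured step bears directly on an exchange of thiophen-3-yl for furan-3-yl, and the only measured step, from amino to methyl, is itself unreadable. With nothing to suggest a gain in inhibition, the expectation is that compound 4 stays at the limit as well, and the step that the limit leaves unreadable from compound 2 to compound 4 is estimated to be indistinguishable from no change. Compound 4 is expected to give about 30000 nM in this assay, within a range from 10000 nM to 100000 nM.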

Compound 4, half-maximal inhibitory concentration: > 20000 nM
Compound 4 was reported as a limit; the forecaster's own chance of this, stated with the estimate: 85%; the middle value lies beyond the limit too.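

Compound 2 and compound 4 both sit at a limit rather than at a number, so the exchange of thiophen-3-yl for furan-3-yl cannot be read in size: the limit of > 20000 nM in this assay, at which 4 of the 4 values shown sit.

The compounds shown leave open how far furan-3-yl and thiophen-3-yl differ in this assay, and which changes to the shared core, if any, would give a readable value.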